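This account rests on a few compounds, and the source may have more. Where it says the series, first, only, none or still open, it means among the compounds named here.

Three close relatives share one core, a six-membered aromatic ring with one nitrogen carrying three aryl groups. Compound 1 `Clc1cccc(-c2cc(-c3ccoc3)cc(-c3ccc(Cl)s3)n2)c1` pairs a 3-chlorophenyl group with a furan-3-yl and a 5-chlorothiophen-2-yl group. In a functional assay on HeLa cells (Homo sapiens) for cytotoxicity, read by ELISA, with a stated time of 4 days (a lower number here means a stronger inhibitor, a higher number a weaker inhibitor), compound 1 gives 23700 nM. Compound 2 `Clc1ccc(-c2cc(-c3ccoc3)cc(-c3ccc(Cl)s3)n2)cc1` differs from compound 1 in one place, (4-chlorophenyl in place of 3-chlorophenyl on an aromatic carbon), and in this assay compound 2 gives 16500 nM, so that a 1.4-fold lower number from compound 1 to compound 2 (0.16 log units; within the scatter). Compound 3 `Clc1cccc(-c2cc(-c3ccc(Cl)o3)cc(-c3ccc(Cl)s3)n2)c1` differs from compound 1 elsewhere, (5-chlorofuran-2-yl in place of furan-3-yl on an aromatic carbon), and in this assay compound 3 gives 25200 nM, making a 1.1-fold higher number from compound 1 to compound 3 (0.03 log units; within the scatter). All three numbers sit close together, and none of the shown steps reaches beyond the usual scatter of this measurement.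

Compound 4 `Clc1ccc(-c2cc(-c3ccc(Cl)o3)cc(-c3ccc(Cl)s3)n2)cc1` has not yet been measured. It stands to compound 3 as compound 2 stands to compound 1: 4-chlorophenyl in place of 3-chlorophenyl on an aromatic carbon. For the measured compounds named here, this is the same kind of change as the one from compound 1 to compound 2, but not the same change, since around its place the surroundings differ, a 5-chlorofuran-2-yl group standing where compound 1 carries a furan-3-yl group. The change from compound 1 to compound 2 made only a small step, so for compound 4 a step of about a 1.4-fold lower number from compound 3 to compound 4 (0.15 log units; within the scatter) is expected, resting on a 1.4-fold lower number from compound 1 to compound 2 (0.16 log units; within the scatter). Compound 4 is therefore estimated at 18000 nM in this assay, with a likely range from 9000 nM to 36000 nM.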

Compound 4, half-maximal inhibitory concentration: 25100 nM
Compound 4: middle estimate off by 1.4-fold (0.14 log units), on the low side, within the range that was stated.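

In this assay, placing 4-chlorophenyl where 3-chlorophenyl stood, on the core that carries 5-chlorofuran-2-yl, gives a 1.0-fold lower number from compound 3 to compound 4 (0.00 log units; within the scatter), and this step cannot be told apart from the one seen earlier on the core with furan-3-yl: the same change on two cores in this assay, a 1.4-fold lower number (0.16 log units; within the scatter) from compound 1 to compound 2 and a 1.0-fold lower number (0.00 log units; within the scatter) from compound 3 to compound 4, 1.4-fold (0.16 log units) apart, within the scatter of two such steps

Read the other way round, placing 5-chlorofuran-2-yl where furan-3-yl stood, on the core that carries 4-chlorophenyl, gives a 1.5-fold higher number from compound 2 to compound 4 (0.18 log units; within the scatter), and again the two steps cannot be told apart: the same change on two cores in this assay, a 1.1-fold higher number (0.03 log units; within the scatter) from compound 1 to compound 3 and a 1.5-fold higher number (0.18 log units; within the scatter) from compound 2 to compound 4, 1.4-fold (0.16 log units) apart, within the scatter of two such steps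

For the compounds shown here, each change therefore stays within the scatter on both cores, which shows that neither one moves the number measurably in these four compounds, but it is only a weak test of carrying a change from core to core, since a change with no measurable step on either core cannot reveal whether a real effect would carry over, and it says nothing about other cores or other assays.

As far as these compounds go, all four compounds keep the 5-chlorothiophen-2-yl group and a chlorine on the phenyl ring, so the effect of changing either remains open. An amine or a carboxylic acid in place of that chlorine, or a plain phenyl without it, might show whether this part of the molecule can shift the number beyond the scatter at all.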